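Leaving 2-chlorophenyl: the step from compound 3 to compound 4

A few compounds are considered here, and "the series" means these few. Any claim that something is new, unique, unknown or untested is made for them only; others in the source may bear on it.

In a functional assay on FM3A cells (Mus musculus) for antiproliferative activity (a higher number here means a weaker inhibitor, a lower number a stronger inhibitor), compound 3 (`COc1cc(C(=O)c2sc(-c3ccccc3Cl)cc2N)cc(OC)c1OC`) gives 34 nM as the lowest number of the three measured, while compound 1 (`COc1cc(C(=O)c2sc(-c3ccc(Cl)cc3)cc2N)cc(OC)c1OC`) gives 90 nM and compound 2 (`COc1cc(C(=O)c2sc(-c3ccncc3)cc2N)cc(OC)c1OC`) gives 150 nM on the same read-out. Compound 4 (`COc1cc(C(=O)c2sc(-c3cccs3)cc2N)cc(OC)c1OC`) has thiophen-2-yl in place of 2-chlorophenyl (thiophen-2-yl in place of 2-chlorophenyl on an aromatic carbon) on an aromatic carbon next to the ring sulfur. Among the measured compounds shown here, two measured steps bear on this (a 2.6-fold lower number from compound 1 to compound 3 (0.42 log units; beyond the scatter)) and (a 4.4-fold lower number from compound 2 to compound 3 (0.64 log units; beyond the scatter)), both modest and both ending at 2-chlorophenyl, while the third (a 1.7-fold higher number from compound 1 to compound 2 (0.22 log units; within the scatter)) stays within the scatter. A modest rise in this assay is therefore expected on leaving 2-chlorophenyl. The expected step (a 2.9-fold higher number from compound 3 to compound 4 (0.47 log units; beyond the scatter)) is an estimate only. For compound 4 the estimated value is 100 nM with a range from 30 nM to 300 nM on this read-out.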

Compound 4, half-maximal inhibitory concentration: 1.7 nM
For compound 4 the middle estimate is 59-fold (1.77 log units) above the measured one, and the stated range ends above it.
By their numbers in this assay, from the lowest: compound 4; then compound 3; then compounds 1 and 2 (each within the scatter of the next).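

Thiophen-2-yl on this aromatic carbon next to the ring sulfur changes this assay far more than any swap among the six-membered rings: a 20-fold lower number from compound 3 to compound 4 (1.30 log units; beyond the scatter), a 53-fold lower number from compound 1 to compound 4 (1.72 log units; beyond the scatter) and an 88-fold lower number from compound 2 to compound 4 (1.95 log units; beyond the scatter), each step large. The earlier steps shown here at this position were modest or within the scatter, so the position allows a much wider span than those compounds showed. No measurement at hand accounts for the gain.

As far as these compounds go, whether the gain follows the sulfur or the five-membered ring remains open. A furan-2-yl group on the same carbon would separate the two.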